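A few compounds are considered here, and "the series" means these few. Any claim that something is new, unique, unknown or untested is made for them only; others in the source may bear on it.

Three compounds have been measured in a functional assay on HCT-116 cells (Homo sapiens) for antiproliferative activity, read by sulforhodamine B assay, with a stated time of 72 h; on this read-out higher numbers stand for weaker inhibition and lower numbers for stronger inhibition:

Compound 1 `Cn1ncc(Cl)c1-c1cc(C(=O)N[C@@H]2CN[C@H](CCN3CCC(O)CC3)C[C@H]2c2ccc(Cl)c(Cl)c2)oc1Cl`: 13700 nM
Compound 2 `Cn1ncc(Cl)c1-c1cc(C(=O)N[C@@H]2CN[C@H](CCN3CCCC3)C[C@H]2c2ccc(Cl)c(Cl)c2)oc1Cl`: 1940 nM
Compound 3 `Cn1ncc(Cl)c1-c1cc(C(=O)N[C@@H]2CN[C@H](CC(=O)NC3CCC3)C[C@H]2c2ccc(Cl)c(Cl)c2)oc1Cl`: 430 nM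

Compound 3 stands lowest of the three numbers. The step of a 4.5-fold lower number from compound 2 to compound 3 (0.65 log units; beyond the scatter) and the step of a 32-fold lower number from compound 1 to compound 3 (1.50 log units; beyond the scatter) both lie beyond the scatter, so compound 3 is the strongest inhibitor among the measured set.

Compound 4 `Cn1ncc(Cl)c1-c1cc(C(=O)N[C@@H]2CN[C@H](CC(=O)NCCO)C[C@H]2c2ccc(Cl)c(Cl)c2)oc1Cl` differs from compound 3 in one place: 2-hydroxyethyl in place of cyclobutyl on an amide-type nitrogen. Within the data shown here, no measured step alters the group on this amide-type nitrogen, so none bears on it directly. Among the measured compounds shown here, the only step that swaps one substituent for another of a different kind, a 7.1-fold lower number from compound 1 to compound 2 (0.85 log units; beyond the scatter), puts pyrrolidin-1-yl in place of 4-hydroxypiperidin-1-yl and lowers the number; the present change goes the other way, from a carbon-only ring to a chain with a hydroxyl. A modest rise in the number is therefore expected, about a 2.3-fold higher number from compound 3 to compound 4 (0.37 log units; beyond the scatter). Compound 4 is estimated at 1000 nM, with a range from 300 nM to 3500 nM.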

Compound 4, half-maximal inhibitory concentration: 670 nM
Compound 4: middle estimate off by 1.5-fold (0.17 log units), on the high side; the range from low to high includes it.
By their numbers in this assay, from the lowest: compounds 3 and 4 (each within the scatter of the next); then compound 2; then compound 1.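

In this assay, putting 2-hydroxyethyl in place of cyclobutyl on the amide-type nitrogen gives a 1.6-fold higher number from compound 3 to compound 4 (0.19 log units; within the scatter) and so leaves the two groups indistinguishable, which shows that neither the four-membered ring nor its carbon-only character is required at this position. The comparisons with the other side chains give a 2.9-fold lower number from compound 2 to compound 4 (0.46 log units; beyond the scatter) and a 20-fold lower number from compound 1 to compound 4 (1.31 log units; beyond the scatter) with the carbamoyl link in place, so a hydroxyl in the side chain does not by itself go with a number as high as that of compound 1. Nothing available explains why cyclobutyl and 2-hydroxyethyl read alike here.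

Still open, from the compounds shown here alone, is how a longer chain, a carboxylic acid or an amine would read on this nitrogen. An ethyl group there would show what the hydroxyl of compound 4 contributes on its own.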